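The source may report more compounds than this note shows. Statements on the series, on what has been measured and on what is new or still open speak of the compounds shown alone.

Compound 1 `O=S(=O)(NCC1CCN(CCCc2c[nH]c3ccc(-n4cnnc4)cc23)CC1)c1ccccc1` is one of three compounds whose efficacy has been measured in a functional assay on CHO cells for activation of 5-hydroxytryptamine receptor 1D (Homo sapiens), read by GTPgammaS binding; a higher number here means a larger maximal response, a lower number a smaller maximal response. In this assay compound 1 gives 73%, the second highest of the three numbers. Compound 2 `O[C@@H]1Cc2ccccc2[C@H]1NC1CCN(CCCc2c[nH]c3ccc(-n4cnnc4)cc23)CC1` gives 75% in this assay, and compound 3 `c1cc(CNC2CCN(CCCc3c[nH]c4ccc(-n5cnnc5)cc34)CC2)co1` gives 65% in this assay. The steps among them are all small: a number 2 percentage points higher from compound 1 to compound 2 (within the scatter), a number 8 percentage points lower from compound 1 to compound 3 (within the scatter) and a number 10 percentage points lower from compound 2 to compound 3 (within the scatter), each within the scatter.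

Compound 4 `C[C@@H](NC1CCN(CCCc2c[nH]c3ccc(-n4cnnc4)cc23)CC1)c1ccccc1` has not yet been measured in this assay. It differs from compound 1 in one place: (1-phenylethyl)amino in place of ((phenylsulfonyl)amino)methyl on a saturated ring carbon. The two measured steps that start from compound 1 bear on this change, since each of them also replaces the ((phenylsulfonyl)amino)methyl group on that saturated ring carbon with an amino group carrying a ring, and neither of them, a number 2 percentage points higher from compound 1 to compound 2 (within the scatter) nor a number 8 percentage points lower from compound 1 to compound 3 (within the scatter), moves beyond the scatter. On that basis no step beyond the scatter is expected for compound 4 either. The expected step is a number 2 percentage points lower from compound 1 to compound 4 (within the scatter). Compound 4 is therefore estimated to give 71% in this assay, with a range from 56% to 86%.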

Compound 4, largest response reached (reported as efficacy), in percent of the reference or control that the assay uses: 90%
For compound 4 the middle estimate is 19 percentage points below the measured one; measured number above the stated range.
By their numbers in this assay, from the lowest: compounds 3, 1 and 2 (each within the scatter of the next); then compound 4.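

In this assay, the saturated ring carbon three ring bonds from the ring nitrogen now proves able to shift the maximal response beyond the scatter, with (1-phenylethyl)amino giving a number 17 percentage points higher from compound 1 to compound 4 (beyond the scatter) in place of ((phenylsulfonyl)amino)methyl. The change is tied to the group on the amine nitrogen and not to the amine alone, since 1-phenylethyl gives a number 25 percentage points higher from compound 3 to compound 4 (beyond the scatter) against (furan-3-yl)methyl and a number 15 percentage points higher from compound 2 to compound 4 (beyond the scatter) against 2-hydroxy-2,3-dihydro-1H-inden-1-yl. Nothing presented here explains this rise.

On these data alone, it remains open whether a plain benzyl group on the amine nitrogen would give the same response, which would show whether the methyl branch of 1-phenylethyl matters. As far as these compounds go, the opposite configuration at the defined stereocentre of 1-phenylethyl is equally open.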